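One Methyl Added to a Weak Cell-Growth Inhibitor

The source may report more compounds than this note shows. Statements on the series, on what has been measured and on what is new or still open speak of the compounds shown alone.

Of the compounds shown here, three built on one shared core have been tested in a functional assay on MCF7 cells (Homo sapiens) for antiproliferative activity, read by MTT assay; a lower number here means a stronger inhibitor, a higher number a weaker inhibitor. Compound 1 `CCCCCCCCCCCCCCCc1cc(=O)c2c(O)c(C)c(O)c(C)c2o1` gave only a limit of this assay, > 67200 nM. Compound 2 `CCCC/C=C\CCCCCCCCCc1cc(=O)c2c(O)c(C)c(OCOC)c(C)c2o1` likewise gave only a limit, > 67200 nM. Going by the values given here, compound 3 `CCCC/C=C\CCCCCCCCCc1cc(=O)c2c(O)c(C)c(O)cc2o1` is the single compound with an actual number, 43200 nM, so it stands as the only measurable point among the three, the other two sitting at the limit of > 67200 nM in this assay, at which 2 of the 3 values shown sit.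

Compound 4 `CCCC/C=C\CCCCCCCCCc1cc(=O)c2c(O)c(C)c(O)c(C)c2o1` has not yet been measured. It differs from compound 3 by methyl in place of hydrogen on an aromatic carbon. Among the compounds with values here, no step between two measured compounds is available, so the size of this change cannot be read directly from the data. Compound 1 also carries two methyl groups on the same core and reached only a limit, > 67200 nM. Compound 4 is therefore expected to stay weak, and the estimated step of a 1.4-fold higher number from compound 3 to compound 4 (0.14 log units; within the scatter) is a small shift toward a weaker inhibitor, near the edge of the usual scatter. For compound 4 the expected value is 60000 nM, within a range of 20000 nM to 180000 nM.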

Compound 4, half-maximal inhibitory concentration: > 67200 nM
Compound 4 was reported as a limit (the forecaster's own chance of this, stated with the estimate: 50%); at least 1.1-fold (0.04 log units) between middle value and limit.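

The swap of hydrogen for methyl on this aromatic carbon, which is ortho to a hydroxy group and para to a hydroxy group, now has its first direct reading in this assay: an at least 1.5-fold higher number from compound 3 to compound 4 (0.19 log units; that floor lies within the scatter). Only a floor is known, and it lies within the scatter, so the methyl may matter little or a great deal; what is clear is that it gives compound 4 no measurable number. Going by these compounds alone, compound 3 therefore remains the only compound with an actual value, and the others gather at one ceiling: the limit of > 67200 nM in this assay, at which 3 of the 4 values shown sit.

The steps linking compound 4 to compound 1 and to compound 2 cannot be read: both ends of each are limits. Also open, from the compounds shown here alone, is how an ethyl group, a chlorine atom or an aminomethyl group on this same aromatic carbon would read in this assay.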